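A few compounds are considered here, and "the series" means these few. Any claim that something is new, unique, unknown or untested is made for them only; others in the source may bear on it.

Measured compounds:
- Compound 1 `C#CCCOC(=O)c1ccc(C(CC)(CC)c2ccc(OCCC(O)(CC)CC)c(C)c2)n1CC`. In a functional assay on PC-3 cells (Homo sapiens) for antiproliferative activity, read by MTT assay, with a stated time of 48 h (a higher number here means a weaker inhibitor, a lower number a stronger inhibitor), compound 1 gives > 50000 nM, which is a limit of the assay rather than a number.
- Compound 2 `CCn1c(C(=O)NC(CC(=O)O)C(=O)OC)ccc1C(CC)(CC)c1ccc(OCCC(O)(CC)CC)c(C)c1`. In this assay compound 2 gives 11200 nM.

From the compounds shown here alone, compound 1 stands only at the limit of > 50000 nM in this assay, at which 1 of the 2 values shown sits, so its true value is unknown beyond that bound. The not yet measured compound 3 `CCn1c(C(=O)NC(C)C(=O)O)ccc1C(CC)(CC)c1ccc(OCCC(O)(CC)CC)c(C)c1` differs from compound 1 in one place: (1-carboxyethyl)amino in place of (but-3-yn-1-yl)oxy on a carbonyl carbon. For the measured compounds named here, the only measured step that bears on this kind of change is the related one in which an ester became an amide bearing an acid, giving an at least 4.4-fold lower number from compound 1 to compound 2 (0.64 log units; beyond the scatter). Compound 3 carries a smaller acid-bearing amide in the same place, so a step of similar direction and size is expected, with wide uncertainty because compound 1 itself sits at the limit of > 50000 nM in this assay, at which 1 of the 2 values shown sits. Compound 3 is expected to give 15000 nM, in the range 4000 nM to 50000 nM. The step of an at least 3.3-fold lower number from compound 1 to compound 3 (0.52 log units; beyond the scatter) is the expected outcome.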

Compound 3, half-maximal inhibitory concentration: 11700 nM
Compound 3: middle estimate off by 1.3-fold (0.11 log units), on the high side; low and high end bracket the measured number.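

In this assay, putting (1-carboxyethyl)amino in place of (but-3-yn-1-yl)oxy on the carbonyl carbon gives an at least 4.2-fold lower number from compound 1 to compound 3 (0.63 log units; beyond the scatter). The true size of this step remains unknown, since compound 1 stands only at a limit of the assay: the limit of > 50000 nM in this assay, at which 1 of the 3 values shown sits.

The group on the amide-type nitrogen is smaller in compound 3 than in compound 2, yet the comparison gives a 1.0-fold higher number from compound 2 to compound 3 (0.02 log units; within the scatter), so the two amides cannot be told apart here.

From the compounds shown here alone, both amides carry a carboxylic acid, so it remains open whether the amide alone accounts for the step or the acid is also needed, a question that an amide ending in a plain methyl group or an amine could address. Also open, going by these compounds, is how a longer chain carrying the acid would read in this assay.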